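Ring-size change on the chain, carried to a second core

The source may report more compounds than this note shows. Statements on the series, on what has been measured and on what is new or still open speak of the compounds shown alone.

Compound 1 `O=C(/C=C/CN1CCCC1)Nc1cc2c(N3CCc4ccccc43)ncnc2cc1O[C@@H]1CCOC1` gives 2310 nM in a functional assay on MCF7 cells (Homo sapiens) for antiproliferative activity, read by MTT assay, with a stated time of 72 h; on this read-out higher numbers stand for weaker inhibition and lower numbers for stronger inhibition. Compound 2 `O=C(/C=C/CN1CCCCC1)Nc1cc2c(N3CCc4ccccc43)ncnc2cc1O[C@@H]1CCOC1` differs from compound 1 only by piperidin-1-yl in place of pyrrolidin-1-yl on a saturated chain carbon bound to a double-bonded chain carbon; in this assay compound 2 gives 1890 nM, so the change made a 1.2-fold lower number from compound 1 to compound 2 (0.09 log units; within the scatter). Compound 3 `COc1cc2ncnc(N3CCCc4ccccc43)c2cc1NC(=O)/C=C/CN1CCCC1` sits on a second core; the difference between the two cores is not broken down here. In this assay compound 3 gives 3190 nM, within the scatter of the other two values. Compound 4 `COc1cc2ncnc(N3CCCc4ccccc43)c2cc1NC(=O)/C=C/CN1CCCCC1` carries the same change on that core: piperidin-1-yl in place of pyrrolidin-1-yl on a saturated chain carbon bound to a double-bonded chain carbon. The place is the same word for word in both pairs, so this is the same change. Because the first pair moved only a 1.2-fold lower number from compound 1 to compound 2 (0.09 log units; within the scatter), the step from compound 3 to compound 4 is expected to be a 1.2-fold lower number from compound 3 to compound 4 (0.07 log units; within the scatter). Compound 4 is estimated at 2700 nM, expected between 1300 nM and 5600 nM.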

Compound 4, half-maximal inhibitory concentration: 3930 nM
Compound 4: middle estimate off by 1.5-fold (0.16 log units), on the low side, within the range that was stated.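

In this assay, piperidin-1-yl in place of pyrrolidin-1-yl on the second core gives a 1.2-fold higher number from compound 3 to compound 4 (0.09 log units; within the scatter). Set beside the step on the first core, the two steps do not differ beyond the scatter: the same change on two cores in this assay, a 1.2-fold lower number (0.09 log units; within the scatter) from compound 1 to compound 2 and a 1.2-fold higher number (0.09 log units; within the scatter) from compound 3 to compound 4, 1.5-fold (0.18 log units) apart, within the scatter of two such steps. The change therefore gives no step beyond the scatter on either core, but this does not show that the two cores would respond alike to a change with a larger step, and it says nothing about a third core.

The compounds shown leave open whether morpholin-4-yl or dimethylamino on the same saturated chain carbon would give a step beyond the scatter. Also open, on these data alone, is whether a longer chain carrying the amine would behave alike on both cores.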